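Adding a Methoxy Group to a Weak Cell Inhibitor

A few compounds are considered here, and "the series" means these few. Any claim that something is new, unique, unknown or untested is made for them only; others in the source may bear on it.

Measured so far:
compound 1 `O=C(Nc1cnn(-c2ccccc2)c1)c1cccc(NS(=O)(=O)c2ccccc2)c1`: 4320 nM
compound 2 `COc1cccc(-n2cc(NC(=O)c3cccc(NS(=O)(=O)c4ccccc4)c3)cn2)c1`: 16700 nM
compound 3 `O=C(Nc1cnn(-c2ccccc2)c1)c1ccc(NS(=O)(=O)c2ccccc2)cc1`: 17100 nM

All three were tested in a functional assay on MCF7 cells (Homo sapiens) for inhibition, read by MTT assay, with a stated time of 48 h; on this read-out higher numbers stand for weaker inhibition and lower numbers for stronger inhibition. Compound 3 gives 17100 nM, the highest number of the three, although compound 2 sits within the scatter of it; compound 1 gives a clearly lower number. Compound 4 `COc1ccc(-n2cc(NC(=O)c3ccc(NS(=O)(=O)c4ccccc4)cc3)cn2)cc1` has not yet been tested. It differs from compound 3 by methoxy in place of hydrogen on an aromatic carbon. For the measured compounds named here, one measured step bears on this change: the same methoxy in place of hydrogen on an aromatic carbon gave a 3.9-fold higher number from compound 1 to compound 2 (0.59 log units; beyond the scatter). A shift of similar size and direction is expected here, so compound 4 is expected to show a step of a 2.6-fold higher number from compound 3 to compound 4 (0.42 log units; beyond the scatter). Compound 4 is therefore estimated at 45000 nM, with a range from 15000 nM to 130000 nM.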

Compound 4, half-maximal inhibitory concentration: 25600 nM
Estimate against measurement, compound 4: 1.8-fold (0.24 log units) above, within the range that was stated.
By their numbers in this assay, from the lowest: compound 1; then compounds 2, 3 and 4 (each within the scatter of the next).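

On the core of compound 3, methoxy in place of hydrogen, para to a large group, gives a 1.5-fold higher number from compound 3 to compound 4 (0.18 log units; within the scatter), a step too small to separate from the noise of repeated measurements. The clear shift seen on the core of compound 1 is therefore not clearly repeated here, yet the two steps cannot be told apart either: the same change on two cores in this assay, a 3.9-fold higher number (0.59 log units; beyond the scatter) from compound 1 to compound 2 and a 1.5-fold higher number (0.18 log units; within the scatter) from compound 3 to compound 4, 2.6-fold (0.41 log units) apart, within the scatter of two such steps

From the compounds shown here alone, whether a different group at this place, such as an amine or a carboxylic acid, would lower the number remains open. For the compounds shown here, with only two examples, it also remains open whether this change depends on the core at all.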